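Three Ureas Measured, a Fourth Still to Come

A few compounds are considered here, and "the series" means these few. Any claim that something is new, unique, unknown or untested is made for them only; others in the source may bear on it.

Compound 1 `Cc1cccc(NC(=O)N[C@@H](C)c2ccccc2)c1` gives 99% in an ADME assay on the whole organism with Oryza sativa as the target, tested at 0.1 uM; on this read-out higher numbers stand for a weaker effect at the one concentration tested and lower numbers for a stronger effect.
Compound 2 `CCc1cccc(NC(=O)N[C@@H](C)c2ccccc2)c1` gives 100% in this assay.
Compound 3 `CCOC(=O)c1cccc(NC(=O)N[C@@H](C)c2ccccc2)c1` gives 100% in this assay.

Compound 3 sits level with compound 2, the two together the highest of the three numbers, although every gap among them is within the usual scatter. Its nearest neighbour is compound 2, with no change at the digits printed from compound 2 to compound 3 (within the scatter); its furthest is compound 1, with a number 1 percentage points higher from compound 1 to compound 3 (within the scatter).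

Compound 4 `C[C@H](NC(=O)Nc1cccc(F)c1)c1ccccc1` has not yet been measured. It differs from compound 3 in one place: fluoro in place of ethoxycarbonyl on an aromatic carbon. The group sits on an aromatic carbon of a six-membered aromatic ring of carbon only, meta to a large group.

Two earlier steps touch that same aromatic carbon. Putting ethoxycarbonyl in place of methyl gave a number 1 percentage points higher from compound 1 to compound 3 (within the scatter), and putting ethoxycarbonyl in place of ethyl gave no change at the digits printed from compound 2 to compound 3 (within the scatter). For the measured compounds named here, neither step exchanges ethoxycarbonyl for fluoro, so no measured pair matches this change directly, but both changes at this carbon left the read-out essentially unmoved. Compound 4 is therefore expected to show no step beyond the scatter, an estimated a number 2 percentage points lower from compound 3 to compound 4 (within the scatter). The expected value for compound 4 is 98%, between 88% and 100%.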

Compound 4, a percentage reported as activity, at one concentration (the size of the read-out at that concentration, not a potency): 97%
The estimate for compound 4 lay 1 percentage points above the measured number; the range from low to high includes it.
By their numbers in this assay, from the lowest: compounds 4, 1, 2 and 3 (each within the scatter of the next).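

For the compounds shown here, compound 4 extends what this aromatic carbon tolerates in this assay to fluoro, a single atom, where the earlier compounds carried only groups built on carbon. Replacing ethoxycarbonyl, with its 5 heavy atoms and 2 hydrogen-bond acceptors, with fluoro gives a number 3 percentage points lower from compound 3 to compound 4 (within the scatter), while fluoro in place of ethyl gives a number 3 percentage points lower from compound 2 to compound 4 (within the scatter) and fluoro in place of methyl gives a number 2 percentage points lower from compound 1 to compound 4 (within the scatter), so the read-out does not separate fluoro from any of the three earlier groups. No measurement is available that would explain this flat result.

As far as these compounds go, whether an amine, a carboxylic acid or a longer chain at this carbon would give a step beyond the scatter remains open. this assay reads a single concentration, and how these compounds would compare at others remains open too.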